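The source may report more compounds than this note shows. Statements on the series, on what has been measured and on what is new or still open speak of the compounds shown alone.

Measured so far in a functional assay on HepG2 cells (Homo sapiens) for inhibition, read by MTT assay, with a stated time of 72 h; on this read-out higher numbers stand for weaker inhibition and lower numbers for stronger inhibition:
compound 1 `CC(C)n1ncc2c(C(=O)Nc3ccccc3)cccc21` gives 23700 nM.
compound 2 `CC(C)n1ncc2c(C(=O)NCc3cn(-c4ccc(F)cc4)nn3)cccc21` gives > 40000 nM, which is a limit of the assay and not a number.
compound 3 `CC(C)n1ncc2c(C(=O)NCc3cn(-c4ccc([N+](=O)[O-])cc4)nn3)cccc21` gives > 40000 nM, again a limit of the assay.

Compound 2 therefore stands at the limit of this assay, with no number of its own. Two of the three values shown sit there, (the limit of > 40000 nM in this assay, at which 2 of the 3 values shown sit). Going by the values given here, the one measured step, a step that the two limits leave unreadable from compound 2 to compound 3, cannot be read because both ends are limits. Compound 4 `CC(C)n1ncc2c(C(=O)NCc3cn(Cc4ccccc4)nn3)cccc21` differs from compound 2 by benzyl in place of 4-fluorophenyl on an aromatic nitrogen. Among the compounds with values here, no measured step bears on this change, so the only guide is where compound 2 stands. Compound 4 is expected to give 40000 nM, in the range 15000 nM to 100000 nM. That means an expected step of a number no higher from compound 2 to compound 4 (the limit leaves the size open), with no direction beyond the scatter, and a further limit is the likeliest outcome.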

Compound 4, half-maximal inhibitory concentration: 13700 nM
Beside the measured number, compound 4's estimate is 2.9-fold (0.47 log units) above it; the measured number lies below the stated range.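

In this assay, benzyl in place of 4-fluorophenyl gives an at least 2.9-fold lower number from compound 2 to compound 4 (0.46 log units; beyond the scatter) and benzyl in place of 4-nitrophenyl gives an at least 2.9-fold lower number from compound 3 to compound 4 (0.46 log units; beyond the scatter) on this aromatic nitrogen, the first readable movement at this position. The group on this nitrogen therefore changes the read-out, with compound 4 the only one of these three to give a number. The values of compound 2 and compound 3 are limits and not numbers, so the step between them cannot be read, and the two new steps fix only a minimum size.

Open, as far as these compounds go, is whether a longer chain such as phenethyl lowers the number further. Also open, from the compounds shown here alone, is whether a substituent on the benzyl ring, such as fluoro or an amine, keeps the number of compound 4.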